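The source may hold more compounds than are shown below. What is called first, only, known or untested is meant among the compounds shown, and "the series" means these compounds.

Working notes on the series. In a functional assay on HEp-2 cells (Homo sapiens) for cytotoxicity (on this read-out higher numbers stand for weaker inhibition and lower numbers for stronger inhibition), compound 1 (`Cc1cc(=O)oc2ccc(OCNc3ccc(F)cc3)cc12`) gives 3620 nM and compound 2 (`Cc1cc(=O)oc2ccc(OCNc3ccccc3O)cc12`) gives 4200 nM. Among the compounds with values here, compound 2 therefore sits within the scatter of compound 1, the only other measured compound, and has no separate rank. Compound 3 (`COc1ccccc1NCOc1ccc2oc(=O)cc(C)c2c1`) departs from compound 2 by methyl in place of hydrogen on an oxygen on an aromatic ring, a change from hydroxy to methoxy. Within the data shown here, the only measured step is a 1.2-fold higher number from compound 1 to compound 2 (0.06 log units; within the scatter). Among the measured compounds shown here, it bears on this change only loosely, since it exchanges the aryl substituents and no measured pair isolates a methyl in place of hydrogen on this oxygen. With that single small step as the guide, no shift beyond the scatter is expected in this assay, and no direction is favoured. The estimated step is a 1.1-fold lower number from compound 2 to compound 3 (0.02 log units; within the scatter). For compound 3 the estimated value is 4000 nM, with an expected range from 1800 nM to 9000 nM.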

Compound 3, half-maximal inhibitory concentration: 5430 nM
Compound 3: middle estimate off by 1.4-fold (0.13 log units), on the low side, within the range that was stated.
By their numbers in this assay, from the lowest: compounds 1, 2 and 3 (each within the scatter of the next).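

Hydroxy to methoxy now has a measured pair of its own, and in this assay methyl in place of hydrogen on this oxygen gives a 1.3-fold higher number from compound 2 to compound 3 (0.11 log units; within the scatter) as the only direct reading of the change. On this read-out, then, the hydrogen on this oxygen can be exchanged for methyl with no shift beyond the scatter, which the earlier step between the aryl substituents could not show. Nothing available explains this result or links it to any property of the two groups.

Still open, as far as these compounds go, is whether a group larger than methyl on this oxygen, such as ethyl or a longer chain, would also stay within the scatter of compound 2. An amine or a carboxylic acid in place of the hydroxy is equally untested by the compounds shown here.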